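The compounds below may be only part of what the source reports. "The series", "measured", "known", "first", "only" and "open" are said of these compounds alone.

In a functional assay on MDA-MB-231 cells (Homo sapiens) for inhibition, read by MTT assay, with a stated time of 72 h (on this read-out lower numbers stand for stronger inhibition and higher numbers for weaker inhibition), compound 1 (`CC(C)=CCC[C@H](C)c1ccc(C)c2c1OCN(CC1CCNCC1)C2`) gives 14900 nM, within the scatter of both compound 2 (`CC(C)=CCC[C@H](C)c1ccc(C)c(CNCC2CCNCC2)c1O`) at 18300 nM and compound 3 (`CC(C)=CCC[C@H](C)c1ccc(C)c(CNCCCCCO)c1O`) at 10700 nM. Compound 4 (`CC(C)=CCC[C@H](C)c1ccc(C)c2c1OCN(CCCCC(=O)O)C2`) differs from compound 1 as follows: 3-carboxypropyl in place of piperidin-4-yl on a saturated chain carbon bound to an amine nitrogen in a ring. For the measured compounds named here, one measured step bears on this, a 1.7-fold lower number from compound 2 to compound 3 (0.23 log units; within the scatter), which also replaces piperidin-4-yl with an open chain, although on a different core and with a hydroxyl end. Going by the values given here, no measured compound besides compound 4 carries the 3-carboxypropyl group, so that precedent is only partial. No change beyond the scatter is therefore expected in this assay, and the estimated step is a 1.1-fold higher number from compound 1 to compound 4 (0.03 log units; within the scatter). For compound 4, the expected value is 16000 nM, with an estimated range of 7500 nM to 35000 nM.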

Compound 4, half-maximal inhibitory concentration: > 50000 nM
Compound 4: only a limit was reported (the forecaster's own chance of this, stated with the estimate: 15%); middle value at least 3.1-fold (0.49 log units) away from the limit.
By their numbers in this assay, from the lowest: compounds 3, 1 and 2 (each within the scatter of the next). At a limit, above all of these: compound 4.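

In this assay, for the compounds shown here, the place on a saturated chain carbon bound to an amine nitrogen in a ring does respond to its group: the one earlier step, on a different core, stayed within the scatter, whereas 3-carboxypropyl in place of piperidin-4-yl brings an at least 3.3-fold higher number from compound 1 to compound 4 (0.52 log units; beyond the scatter). Compound 4 gives > 50000 nM, which is a limit and not a number. The true size of this step therefore stays unfixed, as it rests on a single limit: the limit of > 50000 nM in this assay, at which 1 of the 4 values shown sits.

The compounds shown leave open whether this step goes with the carboxylic acid or with the loss of the piperidin-4-yl ring. An amine or a methyl ester at the end of the same chain, or a longer chain ending in a carboxylic acid, would help to separate the two.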